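Swapping methyl for trifluoromethyl on a sulfonamide aryl ring

The source may hold more compounds than are shown below. What is called first, only, known or untested is meant among the compounds shown, and "the series" means these compounds.

Of the compounds shown here, three have been measured in a functional assay on DU-145 cells (Homo sapiens) for inhibition, read by CCK-8 assay, with a stated time of 72 h; a higher number here means a weaker inhibitor, a lower number a stronger inhibitor. Compound 1, `O=C(/C=C/c1cccnc1)NCCCCCCc1ccc(S(=O)(=O)Nc2ccccc2)cc1`, gives 328 nM, and compound 2, `O=C(/C=C/c1cccnc1)NCCCCCCCc1ccc(S(=O)(=O)Nc2ccccc2)cc1`, gives 438 nM. Compound 3, `Cc1ccc(NS(=O)(=O)c2cccc(CCCCCCNC(=O)/C=C/c3cccnc3)c2)cc1`, gives 34.4 nM, the lowest of the three numbers, and its gaps to compound 1 and to compound 2 both lie beyond the usual scatter, so compound 3 is the strongest inhibitor among them.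

Compound 4, `O=C(/C=C/c1cccnc1)NCCCCCCc1cccc(S(=O)(=O)Nc2ccc(C(F)(F)F)cc2)c1`, has not yet been measured. It differs from compound 3 in one place: trifluoromethyl in place of methyl on an aromatic carbon. Going by the values given here, no measured pair shows what this particular swap does in this assay, so the expectation rests on the shared core of compound 3 and its value of 34.4 nM. The swap is expected to leave the number close to that of compound 3, with any movement not clearly beyond the scatter, as a step of a 1.5-fold higher number from compound 3 to compound 4 (0.16 log units; within the scatter). Compound 4 is therefore estimated to give 50 nM in this assay, within a range from 15 nM to 170 nM.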

Compound 4, half-maximal inhibitory concentration: 1410 nM
For compound 4 the middle estimate is 28-fold (1.45 log units) below the measured one; measured number above the stated range.
By their numbers in this assay, from the lowest: compound 3; then compounds 1 and 2 (each within the scatter of the next); then compound 4.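

In this assay, putting trifluoromethyl in place of methyl gives a 41-fold higher number from compound 3 to compound 4 (1.61 log units; beyond the scatter), a change on an aromatic carbon para to a large group. Going by these compounds alone, no earlier pair differed at this place, so this is the first sign that the number is highly sensitive to the group that sits there: methyl goes with a strong inhibitor, trifluoromethyl with a much weaker one, although neither group adds a ring, a hydrogen-bond donor or acceptor, or a net charge. Within the data shown here, no available measurement explains why this single change moves the number so far.

Going by these compounds, with only these two groups compared here, it remains open whether a chlorine atom, a methoxy group or an amine at this position would stay close to compound 3 or fall toward compound 4. On these data alone, it also remains open how a plain hydrogen at this place would read on the same core.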